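This account rests on a few compounds, and the source may have more. Where it says the series, first, only, none or still open, it means among the compounds named here.

Measured compounds:
compound 1, `CC/C(=C(/c1ccc(/C=C/C(=O)O)cc1)c1cc2ccccc2[nH]1)c1ccccc1Cl`, 42 nM in a functional assay on MCF7 cells (Homo sapiens) for inhibition; on this read-out higher numbers stand for weaker inhibition and lower numbers for stronger inhibition
compound 2, `CC/C(=C(/c1ccc(/C=C/C(=O)O)cc1)c1cc2ccccc2[nH]1)c1ccc(C(F)(F)F)cc1`, 139 nM

Within the data shown here, compound 2 stands at the highest of the two numbers measured in this assay so far; its nearest neighbour is compound 1, and the step of a 3.3-fold higher number from compound 1 to compound 2 (0.52 log units; beyond the scatter) lies beyond the scatter. Compound 3, `CC/C(=C(/c1ccc(/C=C/C(=O)O)cc1)c1cc2ccccc2[nH]1)c1ccc(C#N)cc1Cl`, has not been measured. It differs from compound 2 by 2-chloro-4-cyanophenyl in place of 4-(trifluoromethyl)phenyl on a double-bonded chain carbon bound to a double-bonded chain carbon and a saturated chain carbon.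

Among the measured compounds shown here, only one measured step bears on this change: the step of a 3.3-fold higher number from compound 1 to compound 2 (0.52 log units; beyond the scatter), in which a 2-chlorophenyl group gave way to a 4-(trifluoromethyl)phenyl group at the same place. Compound 3 brings a chlorine back onto that ring, now as part of a 2-chloro-4-cyanophenyl group, while the trifluoromethyl group leaves. For the measured compounds named here, no measured pair shows what a nitrile at that place does, so the expectation rests on the single step alone. On that basis compound 3 is expected to give a somewhat lower number than compound 2, a step of about a 2.3-fold lower number from compound 2 to compound 3 (0.36 log units; beyond the scatter), back toward the value of compound 1, though with wide uncertainty. The estimate for compound 3 in this assay is 60 nM, within a range of 20 nM to 180 nM.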

Compound 3, half-maximal inhibitory concentration: 49 nM
Compound 3: the middle estimate sits 1.2-fold (0.09 log units) above what was measured; measured number inside the range.
By their numbers in this assay, from the lowest: compounds 1 and 3 (each within the scatter of the next); then compound 2.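

In this assay, 2-chloro-4-cyanophenyl in place of 4-(trifluoromethyl)phenyl on this double-bonded chain carbon gives a 2.8-fold lower number from compound 2 to compound 3 (0.45 log units; beyond the scatter), so the higher number of compound 2 is not shared by both groups that differ from 2-chlorophenyl at this place. The earlier compounds shown here held no nitrile, and cyano in place of hydrogen on an aromatic carbon now gives a 1.2-fold higher number from compound 1 to compound 3 (0.07 log units; within the scatter), which shows that the chlorine-bearing ring takes this extra group without a change beyond the scatter. Nothing on hand accounts for either step.

The step from 4-(trifluoromethyl)phenyl changes two things at once, so the compounds shown leave open how much of it belongs to the chlorine entering and how much to the trifluoromethyl group leaving; a 4-cyanophenyl group without chlorine or a 2-chloro-4-(trifluoromethyl)phenyl group would separate the two. They also leave open whether the number would hold with a methoxy group or an amine in place of the nitrile on the 2-chlorophenyl ring.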